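Replacing the dimethoxyphenyl of compound 3 with dichlorophenyl

This account rests on a few compounds, and the source may have more. Where it says the series, first, only, none or still open, it means among the compounds named here.

Compound 3 `COc1ccc(C2CC(c3ccc(OC)c(OC)c3)=NN2C(=O)CO[N+](=O)[O-])c(OC)c1` gives 58% in a functional assay on the whole organism (strain albino) for inhibition, with Rattus norvegicus as the target, read by paw edema, with stated times of 30 min and 3 h, at a dose of 100 mg/kg by the oral route; on this read-out higher numbers stand for more inhibition at the one dose given (going by the name of the read-out) and lower numbers for less inhibition. Within the data shown here, that number is level with the one for compound 1 `COc1ccc(C2=NNC(c3c(Cl)cccc3Cl)C2)cc1OC`, which in this assay gives 58%; together the two are the highest of the three numbers in hand. Compound 2 `COc1ccc(C2=NN(C(=O)CO[N+](=O)[O-])C(c3ccco3)C2)cc1OC` gives 43% in this assay and is the furthest of the three from compound 3. Among the measured compounds shown here, the only step in the set that changes a single place is a number 15 percentage points higher from compound 2 to compound 3 (beyond the scatter), an exchange of the group on a saturated ring carbon, and it lies beyond the scatter.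

Compound 4 `COc1ccc(C2=NN(C(=O)CO[N+](=O)[O-])C(c3c(Cl)cccc3Cl)C2)cc1OC` differs from compound 3 in 2,6-dichlorophenyl in place of 2,4-dimethoxyphenyl on a saturated ring carbon. The step from compound 2 to compound 3 touches the same saturated ring carbon, but it brought in the 2,4-dimethoxyphenyl group that now leaves, so it says little about the 2,6-dichlorophenyl group that enters. Compound 1 already carries a 2,6-dichlorophenyl group on a saturated ring carbon, though without the ((nitrooxy)methyl)carbonyl group, and compound 1 gives 58%, level with compound 3. On that basis no step beyond the scatter is expected in this assay. For compound 4 an inhibition of 56% is estimated, between 42% and 68%. The expected step is a number 2 percentage points lower from compound 3 to compound 4 (within the scatter), within the usual scatter.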

Compound 4, a percentage reported as inhibition, in the whole organism at one dose (the size of the read-out at that dose, not a potency): 58%
For compound 4 the middle estimate is 2 percentage points below the measured one; low and high end bracket the measured number.
By their numbers in this assay, from the lowest: compound 2; then compounds 1, 3 and 4 (each within the scatter of the next).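

At the saturated ring carbon, 2,6-dichlorophenyl in place of 2,4-dimethoxyphenyl gives no change at the digits printed from compound 3 to compound 4 (within the scatter) in this assay, while 2,6-dichlorophenyl in place of furan-2-yl gives a number 15 percentage points higher from compound 2 to compound 4 (beyond the scatter), so the two six-membered aromatic groups read alike here and both stand apart from furan-2-yl. Among these compounds, the new compound also gives the first reading of the ((nitrooxy)methyl)carbonyl group on its own: in place of hydrogen on an amine nitrogen in a ring, it gives no change at the digits printed from compound 1 to compound 4 (within the scatter), so with 2,6-dichlorophenyl in place, this group brings no change in this read-out at the one dose given. Nothing at hand accounts for either the level numbers or the gap to the furan-2-yl compound.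

The compounds shown leave open how an unsubstituted phenyl or a pyridine ring would read at the saturated ring carbon, and whether the ((nitrooxy)methyl)carbonyl group would also leave the number unchanged with furan-2-yl or 2,4-dimethoxyphenyl there. They also leave open how a plain acetyl group on the ring nitrogen would compare with the ((nitrooxy)methyl)carbonyl group.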